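The source may report more compounds than this note shows. Statements on the series, on what has been measured and on what is new or still open speak of the compounds shown alone.

Of the compounds shown here, three sharing one core have been read in a functional assay on A549 cells (Homo sapiens) for cytotoxicity, read by MTT assay, with a stated time of 72 h; on this read-out lower numbers stand for stronger inhibition and higher numbers for weaker inhibition. Within the data shown here, compound 1 (`COc1ccc(Nc2nc3ccccc3nc2S(=O)(=O)c2ccccc2)cc1`) gives 11900 nM, the only true number of the three. Compound 2 (`O=S(=O)(c1ccccc1)c1nc2ccccc2nc1Nc1ccc(C(F)(F)F)cc1`) gives > 50000 nM, which is a limit of the assay. Compound 3 (`COc1ccc(Nc2nc3ccccc3nc2S(=O)(=O)c2ccc(C)cc2)cc1`) gives > 50000 nM, also a limit, so it stands at the limit of > 50000 nM in this assay, at which 2 of the 3 values shown sit.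

Compound 4 (`Cc1ccc(S(=O)(=O)c2nc3ccccc3nc2Nc2cccc(O)c2)cc1`) has 3-hydroxyphenyl in place of 4-methoxyphenyl on a nitrogen on an aromatic ring. Among the measured compounds shown here, two measured steps bear on this, and both end at the limit, so their full sizes are unknown. The step at the same aryl group is an at least 4.2-fold higher number from compound 1 to compound 2 (0.62 log units; beyond the scatter), where trifluoromethyl replaces methoxy. Compound 4 also keeps the methyl of compound 3, which accounts for an at least 4.2-fold higher number from compound 1 to compound 3 (0.62 log units; beyond the scatter). For the measured compounds named here, no measured step shows what a hydroxyl does, and none moves toward a lower number, so only a small shift toward stronger inhibition is expected in this assay, and compound 4 may well stay at the limit. The expected change is an at least 1.7-fold lower number from compound 3 to compound 4 (0.25 log units; that floor lies within the scatter). Compound 4 is estimated at 28000 nM, with an expected range from 9000 nM to 70000 nM.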

Compound 4, half-maximal inhibitory concentration: 6080 nM
Compound 4: the middle estimate sits 4.6-fold (0.66 log units) above what was measured; measured number outside the range, below it.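

In this assay, the exchange of 4-methoxyphenyl for 3-hydroxyphenyl on the nitrogen gives an at least 8.2-fold lower number from compound 3 to compound 4 (0.91 log units; beyond the scatter), the first step shown that runs toward stronger inhibition rather than away from it. The aryl group at this place can therefore do more than lose activity: with the methyl of compound 3 kept, compound 4 gives 6080 nM, a true number and not a limit. The step's full size stays unknown because compound 3 sits at a limit: the limit of > 50000 nM in this assay, at which 2 of the 4 values shown sit.

The exchange alters both the group and where its oxygen sits, so the compounds shown leave open whether the gain belongs to the hydroxyl itself or to its place on the ring. They also leave open whether an amine or a carboxylic acid there would read alike, and whether the hydroxyl would give the same step without the methyl.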